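Swapping Fluoro for Methoxy with Cytotoxicity at the Limit

The source may hold more compounds than are shown below. What is called first, only, known or untested is meant among the compounds shown, and "the series" means these compounds.

Measured so far:
Compound 1 `CCc1ccc2[nH]c(=O)c(CN(Cc3ccc(OCOC)cc3)Cc3ccc(C(C)(C)C)cc3)cc2c1` gives > 10000 nM in a toxicity assay on MDCK cells (Canis lupus familiaris) for cytotoxicity, read by crystal violet staining, with a stated time of 48 h; on this read-out higher numbers stand for lower toxicity in this test and lower numbers for higher toxicity in this test.
Compound 2 `CCc1ccc2[nH]c(=O)c(CN(Cc3ccc(C(C)(C)C)cc3)[C@@H](C)c3ccc(F)cc3)cc2c1` gives > 5000 nM in this assay.

In this assay compound 1 gives > 10000 nM, and this is a limit of the assay rather than a measured number. In this assay compound 2 gives > 5000 nM, likewise a limit and not a number. Within the data shown here, the only step between measured compounds, a step that the two limits leave unreadable from compound 1 to compound 2, therefore cannot be read, since both its ends rest on limits, as the limit of > 10000 nM in this assay, at which 1 of the 2 values shown sits, and the limit of > 5000 nM in this assay, at which 1 of the 2 values shown sits, show. Among the measured compounds shown here, compound 2 thus stands at a limit, and no measured compound has a readable value to compare it with.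

Compound 3 `CCc1ccc2[nH]c(=O)c(CN(Cc3ccc(C(C)(C)C)cc3)[C@@H](C)c3ccc(OC)cc3)cc2c1` differs from compound 2 by methoxy in place of fluoro on an aromatic carbon. For the measured compounds named here, no measured step bears on this change, and no readable step exists at all. Compound 3 is therefore expected to stay at or beyond the limit as well, with an estimated 10000 nM and a range from 5000 nM to 30000 nM. The expected step that the limit leaves unreadable from compound 2 to compound 3 for compound 3 means no change beyond the scatter.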

Compound 3, half-maximal cytotoxic concentration: > 5000 nM
Compound 3 was reported as a limit; the forecaster's own chance of this, stated with the estimate: 80%; the middle value does not contradict the limit.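

Among these compounds, no step among compound 1, compound 2 and compound 3 can be read: in this assay all three values are limits of the assay, not numbers. What remains open is the concentration at which any of these compounds harms the cells, and whether methoxy in place of fluoro makes any difference to it.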